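The compounds below may be only part of what the source reports. "The series", "measured", "known", "first", "only" and "open" are said of these compounds alone.

Two related compounds have so far been measured in a functional assay on ACHN cells (Homo sapiens) for antiproliferative activity, read by sulforhodamine B assay, with a stated time of 48 h; a higher number here means that more compound is tolerated, a lower number that less compound is tolerated. Within the data shown here, compound 1 `Cc1nc(SCC(=O)Nc2nc(-c3ccc(Cl)cc3)cs2)n(Nc2ccccc2)c1C` gives 51500 nM in this assay, and it is the only compound here with a number rather than a limit. Compound 2 `Cc1ccc(Nn2c(SCC(=O)Nc3nc(-c4ccccc4)cs3)nc(C)c2C)cc1` reaches only the limit of this assay, > 100000 nM, which is a limit and not a measured number (the limit of > 100000 nM in this assay, at which 1 of the 2 values shown sits). Compound 3 `COc1ccc(Nn2c(SCC(=O)Nc3nc(-c4ccc(Cl)cc4)cs3)nc(C)c2C)cc1` has not yet been measured in this assay. Compared with compound 1, the change is methoxy in place of hydrogen on an aromatic carbon. Among the measured compounds shown here, no two measured compounds differ in only this one place, so no measured step guides the expectation. Because compound 1 gives 51500 nM in this assay, a value at which a great deal of compound is tolerated, the expected step in this assay is small, a 1.2-fold higher number from compound 1 to compound 3 (0.07 log units; within the scatter), within or only slightly beyond the scatter. Compound 3 is therefore estimated at 60000 nM, with a range from 20000 nM to 150000 nM.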

Compound 3, concentration lethal to 50% of the cells: > 100000 nM
Compound 3: a limit, no number (the forecaster's own chance of this, stated with the estimate: 35%); at least 1.6-fold (0.22 log units) between middle value and limit.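

In this assay compound 3 gives only a limit and not a number, so methoxy on this carbon of the anilino ring, para to a large group, brings no lower number than that of compound 1. The change reads as an at least 1.9-fold higher number from compound 1 to compound 3 (0.28 log units; that floor lies within the scatter), and this is only a floor, as the true value of compound 3 may lie anywhere past the limit. So the one compound with a measured number does not gain from this change, and the compounds shown now sit mostly at the end of the measurable range: the limit of > 100000 nM in this assay, at which 2 of the 3 values shown sit.

Going by these compounds, how far past the limit compound 3 lies stays open, and with it the real size of the step. Also open, on these data alone, is whether an amine or a carboxylic acid on the same ring carbon would give a lower number than compound 1.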